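From benzyl to 3-nitrophenyl on an amine nitrogen

The source may hold more compounds than are shown below. What is called first, only, known or untested is meant among the compounds shown, and "the series" means these compounds.

In a functional assay (aorta) with Rattus norvegicus as the target (a higher number here means a weaker inhibitor, a lower number a stronger inhibitor), compound 1 `CC1(C)Oc2ccc(C#N)cc2[C@@H](/N=C(\NC#N)Oc2ccccc2)[C@@H]1O` reaches only a limit of the assay, > 100000 nM. Going by the values given here, compound 2 `CC1(C)Oc2ccc(C#N)cc2[C@@H](/N=C(\NC#N)NCc2ccccc2)[C@@H]1O` gives 2400 nM, the lowest number so far. Compound 3 `CC1(C)Oc2ccc(C#N)cc2[C@@H](NC(=O)NCc2ccccc2)[C@@H]1O` gives a higher number, 5600 nM.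

Compound 4 `CC1(C)Oc2ccc(C#N)cc2[C@@H](/N=C(\NC#N)Nc2cccc([N+](=O)[O-])c2)[C@@H]1O` has 3-nitrophenyl in place of benzyl on an amine nitrogen. The nearest measured change, an at least 41-fold lower number from compound 1 to compound 2 (1.61 log units; beyond the scatter), was large, but it put benzylamino in place of phenoxy. Compound 4 keeps the amine nitrogen of compound 2, whose value is 2400 nM, so a large loss is not expected. The expected change, a 1.2-fold lower number from compound 2 to compound 4 (0.08 log units; within the scatter), stays within the scatter, though with wide uncertainty. For compound 4 the estimated value is 2000 nM, with an expected range of 350 nM to 12000 nM.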

Compound 4, half-maximal inhibitory concentration: 670 nM
Estimate against measurement, compound 4: 3.0-fold (0.47 log units) above; measured number inside the range.
By their numbers in this assay, from the lowest: compound 4; then compound 2; then compound 3. At a limit, above all of these: compound 1.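

In this assay, the benzyl group on this amine nitrogen is not required, as 3-nitrophenyl gives a 3.6-fold lower number from compound 2 to compound 4 (0.55 log units; beyond the scatter). Compound 1 stands at a limit of the assay, > 100000 nM. Putting (3-nitrophenyl)amino in place of phenoxy gives an at least 140-fold lower number from compound 1 to compound 4 (2.17 log units; beyond the scatter), a gap that is only a bound, and it shows that a second, different group on this amine nitrogen also gives a measurable number.

Benzyl and 3-nitrophenyl differ in more than one feature, so this single step cannot show whether the nitro group matters. A plain phenyl on the same nitrogen would separate the two.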